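The source may report more compounds than this note shows. Statements on the series, on what has been measured and on what is new or still open speak of the compounds shown alone.

In a functional assay on KB cells (Homo sapiens) for cytotoxicity (a higher number here means that more compound is needed for the effect, a lower number that less compound is needed), compound 1 `c1ccc(COc2cc(-c3ccccc3)nc3ccccc23)cc1`, with benzyl on the oxygen, gives 1.6 ug/mL. Compound 2 `CC(C)Oc1cc(-c2ccccc2)nc2ccccc12`, with isopropyl, gives 4.2 ug/mL, and compound 3 `CCCOc1cc(-c2ccccc2)nc2ccccc12`, with propyl, gives 4.5 ug/mL. Compound 3 therefore sits at the upper end of these numbers, level with compound 2 and clear of compound 1. Compound 4 `CC(C)COc1cc(-c2ccccc2)nc2ccccc12` differs from compound 3 by methyl in place of hydrogen on a saturated chain carbon bound to two saturated chain carbons, turning propyl into isobutyl. For the measured compounds named here, the nearest precedent is the change between two small chains, a 1.1-fold higher number from compound 2 to compound 3 (0.03 log units; within the scatter), which stayed within the scatter. Only replacing benzyl gave a modest shift, a 2.8-fold higher number from compound 1 to compound 3 (0.45 log units; beyond the scatter). No shift beyond the scatter is therefore expected, and the estimated change is a 1.1-fold lower number from compound 3 to compound 4 (0.05 log units; within the scatter). The expected value for compound 4 is 4 ug/mL, within an estimated range of 2.2 ug/mL to 7.5 ug/mL.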

Compound 4, half-maximal effective concentration: > 4 ug/mL
Compound 4 ended at the assay's limit; the forecaster's own chance of this, stated with the estimate: 3%; the middle value sits exactly at the limit.
By their numbers in this assay, from the lowest: compound 1; then compounds 2 and 3 (each within the scatter of the next).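

In this assay compound 4 gives > 4 ug/mL, which is a limit of the assay and not a number. The steps to compound 4 from compound 2 and from compound 3 cannot be read, so the added methyl has no measured size here. The comparison with benzyl can still be read, with an at least 2.5-fold higher number from compound 1 to compound 4 (0.39 log units; beyond the scatter), so isobutyl, like propyl and isopropyl, needs more compound than benzyl in compound 1.

As far as these compounds go, whether compound 4 truly sits level with compound 3 stays open. So does how a longer chain or an amine on the oxygen would read.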